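Moving a Methyl Around the Ring: What to Expect

The compounds below may be only part of what the source reports. "The series", "measured", "known", "first", "only" and "open" are said of these compounds alone.

For the measured compounds named here, compound 1 `Cc1nc2sc(Nc3ccccc3)nc2c(=O)[nH]1` holds the higher of the two numbers measured so far in an assay on CHO cells for displacement of a labelled ligand from adenosine receptor A1 (Homo sapiens), read by scintillation counting, with a stated time of 120 min, tested at 1 uM (a lower number here means less inhibition, a higher number more inhibition at the concentration tested (going by the name of the read-out)), where compound 1 gives 24%. Compound 2 `Cc1ccc(Nc2nc3c(=O)[nH]c(C)nc3s2)cc1` gives 20% in this assay, and the step of a number 4 percentage points lower from compound 1 to compound 2 (within the scatter) stays within the scatter. Compound 3 `Cc1cccc(Nc2nc3c(=O)[nH]c(C)nc3s2)c1` differs from compound 1 by methyl in place of hydrogen on an aromatic carbon. Going by the values given here, the only measured step of the same kind, methyl in place of hydrogen on an aromatic carbon, was a number 4 percentage points lower from compound 1 to compound 2 (within the scatter), within the scatter, so no shift beyond the scatter is expected in this assay. Compound 3 is therefore estimated to give 22%, in the range 10% to 35%, an expected step of a number 2 percentage points lower from compound 1 to compound 3 (within the scatter).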

Compound 3, a percentage reported as inhibition, at one concentration (the size of the read-out at that concentration, not a potency): 12%
Compound 3: the middle estimate sits 10 percentage points above what was measured, within the range that was stated.
By their numbers in this assay, from the lowest: compounds 3, 2 and 1 (each within the scatter of the next, the first and the last beyond it).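

In this assay, methyl in place of hydrogen on an aromatic carbon, here meta to a large group, gives a number 12 percentage points lower from compound 1 to compound 3 (beyond the scatter) and thus moves the number beyond the scatter, which the earlier step of this kind did not do. The same change can therefore lower the inhibition at this position, though only modestly. Nothing available here bears on the reason for this result.

From the compounds shown here alone, it remains open whether an ethyl chain, a methoxy group or an amine at this same place would take the number further down or bring it back up. Going by these compounds, it also remains open whether any group on this ring can raise the number above that of compound 1.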